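Halogen and methyl swap on the compound 2 scaffold

This account rests on a few compounds, and the source may have more. Where it says the series, first, only, none or still open, it means among the compounds named here.

Measured in an ADME assay on HeLa cells (Homo sapiens) for inhibition, read by MTT assay; a higher number here means a weaker inhibitor of growth, a lower number a stronger inhibitor of growth:
Compound 1 `Cc1nc(C)c(-c2nn(-c3ccc(F)cc3)cc2/C=C/C(=O)c2cc(Br)ccc2O)s1`: 4.88 ug/mL
Compound 2 `Cc1nc(C)c(-c2nn(-c3ccc(F)cc3)cc2C2CC(c3cc(Br)ccc3O)=NN2)s1`: 21.6 ug/mL

Compound 2 holds the higher of the two numbers in this assay, and its gap to compound 1 lies beyond the usual scatter of repeated measurements. These two compounds differ in more than one place, so their values offer no measured guide to a single substitution.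

Compound 3 `Cc1nc(C)c(-c2nn(-c3ccc(F)cc3)cc2C2CC(c3cc(Cl)c(C)cc3O)=NN2)s1` has not yet been measured. It carries 5-chloro-2-hydroxy-4-methylphenyl in place of 5-bromo-2-hydroxyphenyl on a carbon with a double bond to nitrogen.

For the measured compounds named here, no measured pair shows this change, so the expectation starts from compound 2 at 21.6 ug/mL. A step within the scatter is expected, with no firm direction. The expected change is a 1.2-fold lower number from compound 2 to compound 3 (0.08 log units; within the scatter). For compound 3 the estimated value in this assay is 18 ug/mL, with an expected range of 7 ug/mL to 45 ug/mL.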

Compound 3, concentration for 50% growth inhibition: > 250 ug/mL
Compound 3: no number, only a limit; the forecaster's own chance of this, stated with the estimate: 5%; middle value at least 13-fold (1.14 log units) from the limit.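

In this assay, for the compounds shown here, the exchange of 5-bromo-2-hydroxyphenyl for 5-chloro-2-hydroxy-4-methylphenyl on the carbon with a double bond to nitrogen gives an at least 11-fold higher number from compound 2 to compound 3 (1.06 log units; beyond the scatter), the first single-place step in this set. It shows that growth inhibition in this series is sensitive to the substituents on this phenyl ring, even though the two groups match in hydrogen-bond donors and acceptors and the hydroxyl stays in place. Compound 3 gives only a limit, not a number: the limit of > 250 ug/mL in this assay, at which 1 of the 3 values shown sits.

The step changes the halogen and adds a methyl together, so the compounds shown cannot assign the loss to either alone. On these data alone, whether 5-chloro-2-hydroxyphenyl or 5-bromo-2-hydroxy-4-methylphenyl would stay near compound 2 remains open, as does the effect of a methoxy group or an amine on this ring.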